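A few compounds are considered here, and "the series" means these few. Any claim that something is new, unique, unknown or untested is made for them only; others in the source may bear on it.

Working notes on the series.

Compound 1 `c1ccc(Oc2ncnc3[nH]ccc23)cc1` carries a phenoxy group on its core; in an assay on HEK293-TREx cells for antagonist activity at transient receptor potential cation channel subfamily A member 1 (Homo sapiens), read by fluorescence and calcium flux, with a stated time of 72 h (on this read-out lower numbers stand for stronger inhibition and higher numbers for weaker inhibition), compound 1 gives 3200 nM. Compound 2 `COc1ccc(Oc2ncnc3[nH]ccc23)cc1` adds a methoxy group to that phenoxy ring. For compound 2 the read-out in this assay is a limit of the assay, > 32000 nM, and no number is given (the limit of > 32000 nM in this assay, at which 1 of the 3 values shown sits). The step from compound 2 to compound 1 is therefore only bounded: an at least 10-fold lower number from compound 2 to compound 1 (1.00 log units; beyond the scatter), the change being (hydrogen in place of methoxy on an aromatic carbon).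

Compound 3 `COc1cc2ncnc(Oc3ccc(F)cc3F)c2cc1OC` has a different core, bearing two methoxy groups and a difluorophenoxy group; how its core differs from that of compound 2 is not broken down here. In this assay compound 3 gives 1200 nM, which sits below the number for compound 1 by more than the scatter.

Compound 4 `COc1ccc2ncnc(Oc3ccc(F)cc3F)c2c1` is compound 3 with one methoxy group removed: hydrogen in place of methoxy on an aromatic carbon. This is the same kind of change as from compound 2 to compound 1, but the place is not the same: there the position was on a six-membered aromatic ring of carbon only, para to a large group; here it lies on a fused or bridged system of two rings, ortho to a methoxy group, meta to a fused ring and para to a fused ring. Given that the earlier step of an at least 10-fold lower number from compound 2 to compound 1 (1.00 log units; beyond the scatter) lowered the number but is bounded only by a limit, and that the surroundings differ, the expected step from compound 3 to compound 4 is a 1.3-fold higher number from compound 3 to compound 4 (0.10 log units; within the scatter), a modest shift. Compound 4 is expected near 1500 nM, between 400 nM and 6000 nM.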

Compound 4, half-maximal inhibitory concentration: > 32000 nM
Compound 4: a limit, no number; the forecaster's own chance of this, stated with the estimate: 5%; middle value at least 21-fold (1.32 log units) from the limit.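

Hydrogen in place of methoxy on an aromatic carbon does not carry over from one core to another in this series: in this assay the new step is an at least 26-fold higher number from compound 3 to compound 4 (1.42 log units; beyond the scatter), opposite in direction to the earlier one, an at least 10-fold lower number from compound 2 to compound 1 (1.00 log units; beyond the scatter), and the comparison reads: the same change on two cores in this assay, an at least 10-fold lower number (1.00 log units; beyond the scatter) from compound 2 to compound 1 and an at least 26-fold higher number (1.42 log units; beyond the scatter) from compound 3 to compound 4, at least 260-fold (2.42 log units) apart, beyond the scatter of two such steps

Compound 4 gives > 32000 nM, a limit of the assay and not a number, so the new step, like the earlier one, is bounded on one side only and its full size cannot be read: the limit of > 32000 nM in this assay, at which 2 of the 4 values shown sit.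

The comparison does not show which difference between the two surroundings goes with the reversal, whether the place on the fused system of two rings, ortho to a methoxy group, or another feature of the cores, and two cores give no rule for a third.

From the compounds shown here alone, it remains open whether a hydroxy group, an ethoxy group or an amine at that aromatic carbon would keep compound 3 in its range in this assay. Also open, going by these compounds, is how the same change would read at the other methoxy group of compound 3, or on the core of compound 1 with a difluorophenoxy group.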